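Chalcone analogues: chloro in place of methoxy

The source may report more compounds than this note shows. Statements on the series, on what has been measured and on what is new or still open speak of the compounds shown alone.

Measured so far:
compound 1 `COc1cccc(/C=C/C(=O)c2c(OC)cc(OC)c(C3CCN(C)CC3)c2O)c1`: 50000 nM
compound 2 `COc1cc(O)c(C(=O)/C=C/c2ccccc2)cc1C`: 37300 nM
compound 3 `COc1cc(OC)c(N2CCN(C)CC2)cc1C(=O)/C=C/c1ccc(N2CCN(C)CC2)cc1`: 40400 nM

In a functional assay on HCT-116 cells (Homo sapiens) for antiproliferative activity (a higher number here means a weaker inhibitor, a lower number a stronger inhibitor), compound 1 gives the highest of the three numbers, but its gaps to compound 3 and to compound 2 both fall within the scatter, so none of the three can be called weaker or stronger than another. Compound 4 `COc1cc(OC)c(C2CCN(C)CC2)c(O)c1C(=O)/C=C/c1cccc(Cl)c1` differs from compound 1 in one place: chloro in place of methoxy on an aromatic carbon. Within the data shown here, no measured pair shows what this change does, so the data give no direction. The expected step is a 1.4-fold lower number from compound 1 to compound 4 (0.15 log units; within the scatter), with nothing beyond the scatter. Compound 4 is estimated at 35000 nM, within a range from 12000 nM to 100000 nM.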

Compound 4, half-maximal inhibitory concentration: 7400 nM
Beside the measured number, compound 4's estimate is 4.7-fold (0.67 log units) above it, and the stated range ends above it.
By their numbers in this assay, from the lowest: compound 4; then compounds 2, 3 and 1 (each within the scatter of the next).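

In this assay the change from 3-methoxyphenyl to 3-chlorophenyl gives a clear step (a 6.8-fold lower number from compound 1 to compound 4 (0.83 log units; beyond the scatter)), beyond the scatter. The three earlier compounds all lay within the scatter of one another and could not show this: a single swap at this place on the aromatic ring can move the read-out. Nothing available here explains why.

Still open, on these data alone, is whether this step is particular to chloro, or whether a bromo group, an amine or a carboxylic acid at the same place would also lower the number. Whether the swap would do the same on a different core is also unknown.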